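The compounds below may be only part of what the source reports. "The series", "measured", "known", "first", "only" and "open" are said of these compounds alone.

Measured in a functional assay on HCT-116 cells (Homo sapiens) for inhibition, read by MTT assay, with a stated time of 72 h; on this read-out lower numbers stand for stronger inhibition and higher numbers for weaker inhibition:

- compound 1 `COc1cc(Oc2cccc(Nc3ccccc3)c2)cc(OC)c1CN[C@H](C)c1ccccc1`: > 20000 nM (a limit)
- compound 2 `COc1cc(Oc2cccc(Nc3ccccc3)c2)cc(OC)c1CNCc1ccc(Cl)cc1`: 3310 nM
- compound 3 `COc1cc(Oc2cccc(Nc3ccccc3)c2)cc(OC)c1CNC(C)C`: > 20000 nM (a limit)

Compound 3 is known only as a limit, not as a number. It stands at the limit of > 20000 nM in this assay, at which 2 of the 3 values shown sit.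

Compound 4 `COc1cc(Oc2cccc(Nc3ccccc3)c2)cc(OC)c1CCO` keeps the shared core and changes one part: hydroxymethyl in place of isopropylamino on a saturated chain carbon bound to an aromatic carbon. In words, hydroxymethyl stands in place of isopropylamino, on a saturated chain carbon bound to an aromatic carbon.

The measured steps all swap a group on an amine nitrogen, so they bear on this change only indirectly. Putting 4-chlorobenzyl in place of 1-phenylethyl gave an at least 6.0-fold lower number from compound 1 to compound 2 (0.78 log units; beyond the scatter). Putting isopropyl in place of 4-chlorobenzyl gave an at least 6.0-fold higher number from compound 2 to compound 3 (0.78 log units; beyond the scatter). Both lie beyond the scatter, while the third step is a step that the two limits leave unreadable from compound 1 to compound 3.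

Only compound 2, with its 4-chlorobenzyl group, gives a true number, at 3310 nM, and compound 4 does not carry that group. Going by the values given here, no measured step covers the loss of isopropylamino itself. Little movement is therefore expected, and quite possibly another limit.

The expected change is a number no higher from compound 3 to compound 4 (the limit leaves the size open), with no clear gain in strength anticipated. For compound 4 the estimate is 20000 nM, with an expected range of 7000 nM to 50000 nM.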

Compound 4, half-maximal inhibitory concentration: > 20000 nM
Compound 4: only a limit was reported; the forecaster's own chance of this, stated with the estimate: 65%; the middle value lies on the limit itself.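

In this assay compound 4 gives > 20000 nM, and this value is a limit, not a number. Compound 4 is the first compound here with no amine nitrogen in this side chain, and hydroxymethyl in place of (4-chlorobenzyl)amino on a saturated chain carbon bound to an aromatic carbon gives an at least 6.0-fold higher number from compound 2 to compound 4 (0.78 log units; beyond the scatter), so among these four compounds a true number still appears only for compound 2, with its 4-chlorobenzyl group, while compounds 1, 3 and 4 all stay at the limit. The steps from compound 1 and from compound 3 to compound 4 cannot be read, with a limit at both ends of each: the limit of > 20000 nM in this assay, at which 3 of the 4 values shown sit.

From the compounds shown here alone, whether the nitrogen or the 4-chlorobenzyl group matters more stays open, since compound 4 lacks both, and a 4-chlorobenzyl ether at this place would separate the two. Also open, going by these compounds, is whether a carboxylic acid, an amide or a longer chain on this carbon would bring a readable number.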